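A few compounds are considered here, and "the series" means these few. Any claim that something is new, unique, unknown or untested is made for them only; others in the source may bear on it.

Measured compounds:
compound 1 `CNc1ncnc2c1c(-c1ccsc1)cn2[C@@H]1O[C@H](CO)[C@@H](O)[C@H]1O`, in a functional assay on HeLa S3 cells (Homo sapiens) for antiproliferative activity, read by XTT assay, with a stated time of 72 h (a lower number here means a stronger inhibitor, a higher number a weaker inhibitor), compound 1 gives a limit, > 20000 nM.
compound 2 `CNc1ncnc2c1c(-c1ccccc1)cn2[C@@H]1O[C@H](CO)[C@@H](O)[C@H]1O`; in this assay compound 2 gives a limit, > 20000 nM.
compound 3 `CNc1ncnc2c1c(-c1cccs1)cn2[C@@H]1O[C@H](CO)[C@@H](O)[C@H]1O`; in this assay compound 3 gives a limit, > 20000 nM.

Compound 1 stands only at a limit, with no number behind it. The same holds for the other two, since (the limit of > 20000 nM in this assay, at which 3 of the 3 values shown sit). For the measured compounds named here, the measured steps, a step that the two limits leave unreadable from compound 1 to compound 2, a step that the two limits leave unreadable from compound 1 to compound 3 and a step that the two limits leave unreadable from compound 2 to compound 3, all change the aryl group on the shared core and are unreadable in size, so they give no gauge for any step.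

Compound 4 `Cc1ncnc2c1c(-c1ccsc1)cn2[C@@H]1O[C@H](CO)[C@@H](O)[C@H]1O` differs from compound 1 at another site: methyl in place of methylamino on an aromatic carbon. Going by the values given here, no measured step touches this position, and the aryl steps show nothing beyond two limits. The step from compound 1 to compound 4 is therefore expected to be unreadable as well, most likely ending at the same limit; the expected step is a step that the limit leaves unreadable from compound 1 to compound 4. Compound 4 is expected in this assay at 30000 nM, within 10000 nM to 100000 nM.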

Compound 4, half-maximal inhibitory concentration: 14300 nM
Compound 4: the middle estimate sits 2.1-fold (0.32 log units) above what was measured; the measured number falls inside the stated range.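

In this assay, for the compounds shown here, compound 4 gives 14300 nM, the first number rather than a limit, and it appears at the position on the six-membered aromatic ring, not on the aryl group. Methyl in place of methylamino gives an at least 1.3-fold lower number from compound 1 to compound 4 (0.14 log units; that floor lies within the scatter), so only a floor is known, and the true size of the step remains unread. The steps among compound 1, compound 2 and compound 3 cannot be read, and this change is the only one shown that leaves the limit: the limit of > 20000 nM in this assay, at which 3 of the 4 values shown sit.

Going by these compounds, whether an unsubstituted amine, a methoxy group or a longer chain at this position gives a lower number stays open. Also open, on these data alone, is whether methyl paired with phenyl or thiophen-2-yl on the shared core gives a number as well.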